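A few compounds are considered here, and "the series" means these few. Any claim that something is new, unique, unknown or untested is made for them only; others in the source may bear on it.

Notes on the series. In an ADME assay on BJ cells (Homo sapiens) for cytotoxicity, read by CellTiter-Glo and resazurin assay, with a stated time of 72 h (on this read-out higher numbers stand for an effect only at larger amounts of compound and lower numbers for an effect already at smaller amounts), compound 1 `CC(C)N(Cc1cccc(OCCCCCC(=O)O)c1)C(=O)c1ccc(-c2ccncc2)cc1` gives > 26000 nM, which is a limit of the assay and not a number. Compound 2 `CC(=O)c1cccc(-c2ccc(C(=O)N(Cc3cccc(OCCCCCC(=O)O)c3)C(C)C)cc2)c1` gives > 26000 nM, again a limit. Compound 3 `CCOC(=O)CCCCCOc1cccc(CN(C(=O)c2ccc(-c3cccc(C(C)=O)c3)cc2)C(C)C)c1` gives > 26000 nM, also a limit. All three therefore sit together at the limit of > 26000 nM in this assay, at which 3 of the 3 values shown sit. The two measured steps a step that the two limits leave unreadable from compound 1 to compound 2 and a step that the two limits leave unreadable from compound 2 to compound 3 have no readable size, both their ends being limits. Compound 4 `CCOC(=O)CCCCCOc1cccc(CN(C(=O)c2ccc(-c3cccc(C(F)(F)F)c3)cc2)C(C)C)c1` differs from compound 3 by trifluoromethyl in place of acetyl on an aromatic carbon. Among the compounds with values here, no measured step bears on this change, and no step has a readable size, so the expected step that the limit leaves unreadable from compound 3 to compound 4 carries no direction beyond the scatter. Compound 4 is thus expected near 30000 nM, within 15000 nM to 80000 nM, most probably reported again only as a limit.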

Compound 4, half-maximal effective concentration: < 1.3 nM
Compound 4: a limit, no number (the forecaster's own chance of this, stated with the estimate: 75%); at least 23000-fold (4.36 log units) between middle value and limit.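

In this assay, within the data shown here, the change from 3-acetylphenyl to 3-(trifluoromethyl)phenyl gives an at least 20000-fold lower number from compound 3 to compound 4 (4.30 log units; beyond the scatter) and is the only readable step, the earlier steps being unreadable. The group on this aromatic carbon can therefore move the read-out a long way with the ethyl ester in place, which compounds 1, 2 and 3 could not show. Compound 4 alone sits at a limit on the low side, and that limit is not a number: the limit of < 1.3 nM in this assay, at which 1 of the 4 values shown sits.

Still open, as far as these compounds go, is whether trifluoromethyl gives a comparable step with a carboxylic acid in place of the ethyl ester. Also open, from the compounds shown here alone, is whether a nitrile or a chlorine on this aromatic carbon gives such a step.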